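The source may report more compounds than this note shows. Statements on the series, on what has been measured and on what is new or still open speak of the compounds shown alone.

Of the compounds shown here, three sharing one core have been measured so far. In a physicochemical assay for solubility (a lower number here means a less soluble compound, a higher number a more soluble compound), compound 1 `O=C(CN1CCCC1)N1CCC(NS(=O)(=O)c2cc(S(=O)(=O)c3ccccc3)ccc2C(F)(F)F)CC1` gives 25000 nM, compound 2 `O=C(CN1CCNCC1)N1CCC(NS(=O)(=O)c2cc(S(=O)(=O)c3ccccc3)ccc2C(F)(F)F)CC1` gives 50000 nM, and compound 3 `CN(C)CC(=O)N1CCC[C@H]1C(=O)N1CCC(NS(=O)(=O)c2cc(S(=O)(=O)c3ccccc3)ccc2C(F)(F)F)CC1` gives 100000 nM. Compound 3 stands clear of only one of the other two: a 4.0-fold higher number from compound 1 to compound 3 (0.60 log units; beyond the scatter) is a modest but real step, whereas a 2.0-fold higher number from compound 2 to compound 3 (0.30 log units; within the scatter) stays within the scatter, as does a 2.0-fold higher number from compound 1 to compound 2 (0.30 log units; within the scatter).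

Compound 4 `CC(C)(C)NC(=O)N1CCC[C@H]1C(=O)N1CCC(NS(=O)(=O)c2cc(S(=O)(=O)c3ccccc3)ccc2C(F)(F)F)CC1` changes one group of compound 3: (tert-butyl)amino in place of (dimethylamino)methyl on a carbonyl carbon. The (tert-butyl)amino group takes the place of (dimethylamino)methyl on a carbonyl carbon, turning ((dimethylamino)methyl)carbonyl into (tert-butyl)carbamoyl.

Going by the values given here, no measured step makes this exact change, so the evidence is indirect. The nearest guides are a 4.0-fold higher number from compound 1 to compound 3 (0.60 log units; beyond the scatter) and a 2.0-fold higher number from compound 2 to compound 3 (0.30 log units; within the scatter), which both bring in the group now being altered, and both are small. Each measured compound carries an amino group on a saturated chain carbon bound to a carbonyl carbon, and compound 4 does not, so nothing measured covers this case. A modest fall from the 100000 nM of compound 3 is expected in this assay, although this is uncertain. The expected step is a 3.3-fold lower number from compound 3 to compound 4 (0.52 log units; beyond the scatter). For compound 4 the estimate is 30000 nM, with an expected range from 8000 nM to 90000 nM.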

Compound 4, solubility: 50000 nM
For compound 4 the middle estimate is 1.7-fold (0.22 log units) below the measured one; the measured number falls inside the stated range.
By their numbers in this assay, from the lowest: compounds 1, 2, 4 and 3 (each within the scatter of the next, the first and the last beyond it).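

In this assay, going by these compounds alone, putting (tert-butyl)amino in place of (dimethylamino)methyl on this carbonyl carbon gives a 2.0-fold lower number from compound 3 to compound 4 (0.30 log units; within the scatter) and so does not move the number beyond the scatter, even though compound 4 lacks the amino group on a saturated chain carbon that all the earlier compounds carry. That group is therefore not needed for a number in this range, and the comparisons with the other two compounds agree: no change at the digits printed from compound 2 to compound 4 (within the scatter) and a 2.0-fold higher number from compound 1 to compound 4 (0.30 log units; within the scatter) are also both within the scatter, so compound 4 cannot be told apart from any of the three. Nothing measured here explains why the number holds across this change.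

As far as these compounds go, it remains open whether a smaller group on the same carbonyl carbon, such as methylamino, or a different kind of group, such as a carboxylic acid on a short chain, would give a step beyond the scatter. These four compounds also cannot show whether the (tert-butyl)carbamoyl group would behave the same way on a core with a different substituent in place of the phenylsulfonyl group.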